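A few compounds are considered here, and "the series" means these few. Any claim that something is new, unique, unknown or untested is made for them only; others in the source may bear on it.

Among the compounds with values here, in a functional assay on LoVo cells (Homo sapiens) for inhibition, read by MTT assay, with a stated time of 72 h (a higher number here means a weaker inhibitor, a lower number a stronger inhibitor), compound 2 (`C=C(Br)C(=O)Nc1cccc(/C=C/C(=O)Nc2ccc(F)c(F)c2)c1`) gives 540 nM, the lower of the two numbers so far, while compound 1 (`C=C(Br)C(=O)Nc1cccc(/C=C/C(=O)Nc2ccc(F)cc2)c1`) gives 4800 nM. Compound 3 (`C=C(Br)C(=O)Nc1cccc(/C=C/C(=O)Nc2ccc(Cl)cc2)c1`) carries 4-chlorophenyl in place of 3,4-difluorophenyl on an amide-type nitrogen. Within the data shown here, the only measured step that bears on this is an 8.9-fold lower number from compound 1 to compound 2 (0.95 log units; beyond the scatter), where a fluoro replaced a hydrogen on an aromatic carbon. Among the measured compounds shown here, compound 3, like compound 1, has one halogen on that ring, but no measured compound carries chlorine, so the size stays uncertain. In this assay, the expected change is moderate and upward, a 3.0-fold higher number from compound 2 to compound 3 (0.47 log units; beyond the scatter). Compound 3 is estimated at 1600 nM, within an expected range of 450 nM to 5500 nM.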

Compound 3, half-maximal inhibitory concentration: 5900 nM
Estimate against measurement, compound 3: 3.7-fold (0.57 log units) below, and the stated range ends below it.
By their numbers in this assay, from the lowest: compound 2; then compounds 1 and 3 (each within the scatter of the next).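

In this assay, the change on the amide-type nitrogen from 3,4-difluorophenyl to 4-chlorophenyl gives an 11-fold higher number from compound 2 to compound 3 (1.04 log units; beyond the scatter), about as large as the gain seen on adding the second fluoro. Exchanging the single halogen, chloro in place of fluoro, gives a 1.2-fold higher number from compound 1 to compound 3 (0.09 log units; within the scatter), so among these compounds only the 3,4-difluorophenyl group stands apart. Nothing shown explains this difference. Still open, going by these compounds, is whether 3,4-dichlorophenyl would match 3,4-difluorophenyl. How plain phenyl, or a ring carrying methoxy or an amine, would compare is also unknown.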